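Amide replacements for the propylcarbonyl group

The source may report more compounds than this note shows. Statements on the series, on what has been measured and on what is new or still open speak of the compounds shown alone.

Measured so far in a functional assay for inhibition of nuclear factor NF-kappa-B complex (Homo sapiens); on this read-out lower numbers stand for stronger inhibition and higher numbers for weaker inhibition:
- Compound 1, `CCCC(=O)C1=Cc2ccc(OC)cc2OC1c1cc(OC)c(OC)c(OC)c1`: compound 1 gives 11700 nM.
- Compound 2, `CCNC(=O)C1=Cc2ccc(OC)cc2OC1c1cc(OC)c(OC)c(OC)c1`: for compound 2 the assay reports only a limit, > 50000 nM.
- Compound 3, `COc1ccc2c(c1)OC(c1cc(OC)c(OC)c(OC)c1)C(C(=O)N(C)C)=C2`: for compound 3 the assay likewise reports only a limit, > 50000 nM.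

Going by the values given here, compound 1 thus holds the only number in this assay; the two other values are limits, which the limit of > 50000 nM in this assay, at which 2 of the 3 values shown sit, records. Both steps away from compound 1 go the same way: an at least 4.2-fold higher number from compound 1 to compound 2 (0.63 log units; beyond the scatter) and an at least 4.2-fold higher number from compound 1 to compound 3 (0.63 log units; beyond the scatter).

Compound 4, `CNC(=O)C1=Cc2ccc(OC)cc2OC1c1cc(OC)c(OC)c(OC)c1`, follows the same line of change: methylamino in place of propyl on a carbonyl carbon. Both measured amide steps were at least modest rises, so a rise beyond the scatter is expected here too, most likely again up to the limit. Compound 4 is therefore estimated at 50000 nM, expected between 20000 nM and 120000 nM. The expected step is a 4.3-fold higher number from compound 1 to compound 4 (0.63 log units; beyond the scatter).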

Compound 4, half-maximal inhibitory concentration: > 50000 nM
Compound 4 was reported as a limit; the forecaster's own chance of this, stated with the estimate: 70%; the middle value lies on the limit itself.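

In this assay methylcarbamoyl in place of propylcarbonyl gives an at least 4.2-fold higher number from compound 1 to compound 4 (0.63 log units; beyond the scatter) and thus extends the loss seen with ethylamino and dimethylamino to the methylamino amide. Among the amides shown, all three changes on this carbonyl carbon leave no measurable number. Compound 4 is reported only as a limit, as are compound 2 and compound 3, so the steps among these three cannot be read: the limit of > 50000 nM in this assay, at which 3 of the 4 values shown sit.

Any order among these amides stays open. Also open, on these data alone, is whether a butyl or cyclopropyl ketone, or a methyl ester, at this carbonyl carbon would give a lower number than compound 1.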